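The source may hold more compounds than are shown below. What is called first, only, known or untested is meant among the compounds shown, and "the series" means these compounds.

Measured so far:
Compound 1 `CN1CCC(c2c[nH]c3ccc(NC(=O)c4ccncc4)nc23)CC1`: in an assay for binding affinity to 5-hydroxytryptamine receptor 1F (Homo sapiens), read by radioligand binding (on this read-out lower numbers stand for stronger inhibition and higher numbers for weaker inhibition), compound 1 gives 8.4 nM.
Compound 2 `CCCCC(=O)Nc1ccc2[nH]cc(C3CCN(C)CC3)c2n1`: in this assay compound 2 gives 14 nM.

Of these two numbers compound 2 holds the higher one, but a 1.7-fold higher number from compound 1 to compound 2 (0.22 log units; within the scatter) lies within the scatter, so the two compounds are not told apart. Compound 3 `CN1CCC(c2c[nH]c3ccc(NC(=O)C(C)(C)C)nc23)CC1` differs from compound 2 by tert-butyl in place of butyl on a carbonyl carbon. Among the measured compounds shown here, no measured step alters the shape of this chain: the only known step exchanged an aromatic ring for the butyl and stayed within the scatter, so no step beyond the scatter is expected here. Compound 3 is thus estimated at 14 nM (range 5 nM to 40 nM), an expected step of no change at the digits printed from compound 2 to compound 3 (within the scatter).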

Compound 3, inhibition constant: 62 nM
Estimate against measurement, compound 3: 4.4-fold (0.65 log units) below; the measured number lies above the stated range.
By their numbers in this assay, from the lowest: compounds 1 and 2 (each within the scatter of the next); then compound 3.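

In this assay, the carbonyl carbon turns out not to tolerate every chain alike: butyl and tert-butyl are the same atoms joined differently, yet that change alone gives a 4.4-fold higher number from compound 2 to compound 3 (0.65 log units; beyond the scatter). The earlier pair had stayed within the scatter, whereas tert-butyl in place of pyridin-4-yl gives a 7.4-fold higher number from compound 1 to compound 3 (0.87 log units; beyond the scatter). Nothing available explains this loss. Still open, from the compounds shown here alone, is whether isopropyl or cyclopropyl on the carbonyl carbon would track compound 2 or compound 3. A longer chain such as hexyl, or an amine there, is equally unresolved.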